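This account rests on a few compounds, and the source may have more. Where it says the series, first, only, none or still open, it means among the compounds named here.

Measured compounds:
Compound 1, `O=Cc1ccc(-c2cn3ccnc3c(-c3ccc4ncn(C5CCCCC5)c4c3)n2)cc1`: 36.6%
Compound 2, `O=Cc1ccc(-c2cn3ccnc3c(-c3ccc4ncn(Cc5ccccc5)c4c3)n2)cc1`: 36.6%
Compound 3, `c1cn2cc(-c3ccc4c(c3)ncn4C3CCCCC3)nc(-c3ccc4ncn(C5CCCCC5)c4c3)c2n1`: 15.9%

The three measured compounds were tested in a functional assay on CAKI-1 cells (Homo sapiens) for inhibition, read by sulforhodamine B assay, with a stated time of 48 h, tested at 10 uM; a lower number here means less inhibition, a higher number more inhibition at the concentration tested (going by the name of the read-out). Compound 1 and compound 2 share one core and differ in a single place: benzyl in place of cyclohexyl on an aromatic nitrogen. This change left the read-out where it was, no change at the digits printed from compound 1 to compound 2 (within the scatter), so within this pair the cyclohexyl and the benzyl give the same result within the usual scatter.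

Compound 3 carries a different core; how the core of compound 3 and the core of compound 1 differ is not broken down here. In this assay compound 3 gives 15.9%, the lowest of the three numbers, and its distance from compound 1 and from compound 2 lies beyond the scatter.

Compound 4, `c1ccc(Cn2cnc3ccc(-c4nc(-c5ccc6c(c5)ncn6C5CCCCC5)cn5ccnc45)cc32)cc1`, has not yet been measured. It stands to compound 3 as compound 2 stands to compound 1: benzyl in place of cyclohexyl on an aromatic nitrogen. The place of the change is described in the same words in both pairs, so this is the same change, made for the second time among these compounds. Because the earlier step, no change at the digits printed from compound 1 to compound 2 (within the scatter), showed no change within the scatter, the step from compound 3 to compound 4 is expected to be small as well, a number 1.1 percentage points higher from compound 3 to compound 4 (within the scatter). Compound 4 is therefore estimated to give 17% in this assay. For compound 4 the expected range runs from 5% to 32%. This rests on a single earlier pair, and a different core may respond differently.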

Compound 4, a percentage reported as inhibition, at one concentration (the size of the read-out at that concentration, not a potency): 56.7%
Estimate against measurement, compound 4: 39.7 percentage points below, outside the stated range (above it).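

In this assay, benzyl in place of cyclohexyl on an aromatic nitrogen gave a clear result on the second core, where the step reads a number 40.8 percentage points higher from compound 3 to compound 4 (beyond the scatter). Set beside the earlier pair, this shows that the size of the change did not carry over from one core to the other in this series: the same change on two cores in this assay, no change at the digits printed (within the scatter) from compound 1 to compound 2 and a number 40.8 percentage points higher (beyond the scatter) from compound 3 to compound 4, 40.8 percentage points apart, beyond the scatter of two such steps. Among the compounds shown here, it does not show which difference between the cores lies behind this, and with only two pairs, each read at a single concentration, it cannot say how the change would behave on a third core or whether the gap would hold as a difference in potency.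

The compounds shown leave open how the two cores would respond to other groups on that aromatic nitrogen, such as a longer alkyl chain or a chain ending in an amine, which could show whether the gain on the core of compound 3 is particular to benzyl. They also leave open whether a carboxylic acid in place of the aldehyde on the core of compound 1 would alter that core's indifference to this change.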